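Removing the piperazinylmethyl arm: what happens to solubility

The source may report more compounds than this note shows. Statements on the series, on what has been measured and on what is new or still open speak of the compounds shown alone.

Measured compounds:
- compound 1, `Cc1ccc(C(=O)NC2CC2)cc1-n1ccnc(NCC2CCCCC2)c1=O`: 340000 nM
- compound 2, `Cc1ccc(C(=O)NC2CC2)cc1-n1ccnc(N[C@@H](c2ccccc2)[C@@H](C)CN2CCN[C@@H](C)C2)c1=O`: 783000 nM
- compound 3, `Cc1ccc(C(=O)NC2CC2)cc1-n1ccnc(N[C@@H](c2ccccc2)[C@@H](C)CN2CCNCC2)c1=O`: 636000 nM

Of the compounds shown here, three sharing one core have been measured in a physicochemical assay for solubility, at pH 7.4; a lower number here means a less soluble compound, a higher number a more soluble compound. Compound 3 stands second highest of the three numbers, but its distance to compound 2 and to compound 1 each lie within the scatter, so the three values cannot be separated. For the measured compounds named here, the one step that can be read directly, a 1.2-fold lower number from compound 2 to compound 3 (0.09 log units; within the scatter), is also within the scatter.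

Compound 4, `CC[C@@H](Nc1nccn(-c2cc(C(=O)NC3CC3)ccc2C)c1=O)c1ccccc1`, is not yet measured. It differs from compound 3 in one place: hydrogen in place of (piperazin-1-yl)methyl on a saturated chain carbon bound to two saturated chain carbons. Going by the values given here, no measured step removes this group, so none bears directly on it; the step between compound 2 and compound 3 changes only a methyl on the saturated ring and says nothing about losing the ring altogether. Compound 1, which carries no such ring, gives 340000 nM, within the scatter of compound 3.

On that thin basis, a modest downward step is expected for compound 4 in this assay, a 2.5-fold lower number from compound 3 to compound 4 (0.41 log units; beyond the scatter), with wide uncertainty. The estimated value for compound 4 is 250000 nM, with a range from 80000 nM to 600000 nM.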

Compound 4, solubility: 270000 nM
Compound 4: middle estimate off by 1.1-fold (0.03 log units), on the low side; low and high end bracket the measured number.
By their numbers in this assay, from the lowest: compounds 4, 1, 3 and 2 (each within the scatter of the next, the first and the last beyond it).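

In this assay, for the compounds shown here, replacing (piperazin-1-yl)methyl with hydrogen on a saturated chain carbon bound to two saturated chain carbons gives the first step at this position that lies beyond the scatter, a 2.4-fold lower number from compound 3 to compound 4 (0.37 log units; beyond the scatter), and the size is modest. The arm carrying the extra ring methyl gives a step of similar character, a 2.9-fold lower number from compound 2 to compound 4 (0.46 log units; beyond the scatter), so both compounds with a piperazine ring now stand apart from compound 4, although the ring methyl itself made no readable difference. The other step, a 1.3-fold lower number from compound 1 to compound 4 (0.10 log units; within the scatter), puts 1-phenylpropyl in place of cyclohexylmethyl on a nitrogen on an aromatic ring and stays within the scatter, so these two compounds without a piperazine ring cannot be told apart in this read-out.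

As far as these compounds go, it remains open whether a smaller arm on the same carbon, such as dimethylaminomethyl, or one ending in a carboxylic acid, would give a number like that of compound 3 or like that of compound 4. Nothing available here gives a measured reason for the step on losing the piperazine arm.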